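The compounds below may be only part of what the source reports. "The series", "measured", "known", "first", "only" and "open" are said of these compounds alone.

Working notes on the series. Three compounds have numbers in a functional assay on the whole organism (strain Swiss) with Mus musculus as the target, in the maximal electroshock model, with a stated time of 1 h, at a dose of 100 mg/kg by the intraperitoneal route; on this read-out higher numbers stand for a stronger effect at the one dose given and lower numbers for a weaker effect. Compound 1 `COCC(C(=O)N1CCN(c2cccc(C(F)(F)F)c2)CC1)N1C(=O)CCC1=O` gives 50%, the highest of the three. Compound 3 `CC(C(=O)N1CCN(c2ccccc2C(F)(F)F)CC1)N1C(=O)CCC1=O` gives 25%, the nearest number to compound 1 but lower by a margin beyond the scatter. Compound 2 `CC(C(=O)N1CCN(c2ccc(Cl)cc2)CC1)N1C(=O)CCC1=O` gives 0% and lies furthest from compound 1, again beyond the scatter. Within the data shown here, no two of these differ in one place only, so no single step between measured compounds can be read off; compound 2 and compound 3 each differ from compound 1 in more than one place.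

Compound 4 `CCC(C(=O)N1CCN(c2cccc(C(F)(F)F)c2)CC1)N1C(=O)CCC1=O` is the next compound for this assay. It differs from compound 1 in one place: methyl in place of methoxy on a saturated chain carbon, two bonds along the chain from an amide-type nitrogen in a ring and a carbonyl carbon. Among the measured compounds shown here, no step of this kind exists among the measured compounds, so its size and direction are open. Compound 2 and compound 3 both carry the methyl rather than the methoxy and both sit lower than compound 1, but their aryl groups differ as well, so this is only a loose hint.

The expected step of a number 10 percentage points lower from compound 1 to compound 4 (within the scatter) is a modest decrease that may not exceed the scatter. Compound 4 is estimated at 40% in this assay, with a range from 10% to 70%.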

Compound 4, a percentage reported as activity, at one dose (the size of the read-out at that dose, not a potency): 0%
Compound 4: the middle estimate sits 40 percentage points above what was measured; measured number outside the range, below it.
By their numbers in this assay, from the lowest: compounds 2 and 4 (each within the scatter of the next); then compound 3; then compound 1.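

In this assay, among these compounds, methyl in place of methoxy on the saturated chain carbon gives a number 50 percentage points lower from compound 1 to compound 4 (beyond the scatter), the first step that can be read at a single place. This position alone can therefore separate a clear effect from none at the one dose given, which compounds 2 and 3 could not show, as their aryl groups differ from that of compound 1 as well. Nothing measured here accounts for the size of this step.

The same difference reads methoxymethyl to ethyl, so the compounds shown do not separate the presence of the oxygen from other features of the chain; hydroxymethyl, propyl or aminomethyl at this carbon would bear on that. As far as these compounds go, whether the step holds with other aryl groups also stays open, as it is read on one pair only.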